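A few compounds are considered here, and "the series" means these few. Any claim that something is new, unique, unknown or untested is made for them only; others in the source may bear on it.

Measured compounds:
- compound 1 `O=C(Nc1ccc(-n2ncc3c(Br)cccc32)cc1)Nc1ccc(Cl)c(C(F)(F)F)c1`: 1300 nM
- compound 2 `O=C(Nc1ccc(-n2ncc3c(C(F)(F)F)cccc32)cc1)Nc1ccc(C(F)(F)F)cc1`: 1000 nM

Both compounds were tested in a functional assay on Bel-7402 cells (Homo sapiens) for cytotoxicity, read by MTT assay, with a stated time of 72 h; a lower number here means a stronger inhibitor, a higher number a weaker inhibitor. In this assay compound 1 gives 1300 nM, the higher of the two numbers shown, and compound 2 gives 1000 nM; the gap between them lies within the scatter of repeated measurements, so the two compounds cannot be told apart on these data.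

Compound 3 `O=C(Nc1ccc(-n2ncc3ccncc32)cc1)Nc1ccc(Cl)c(C(F)(F)F)c1` has not yet been measured. It differs from compound 1 in one place: a group of 9 heavy atoms (6 carbon, 3 nitrogen; one five-membered aromatic ring with 2 hetero atoms, one six-membered aromatic ring with 1 hetero atom) in place of a group of 10 heavy atoms (7 carbon, 2 nitrogen, 1 bromine; one five-membered aromatic ring with 2 hetero atoms, one six-membered aromatic ring of carbon only), on an aromatic carbon. The group that leaves is the 4-bromo-1H-indazol-1-yl group, and the group that enters sits on the same aromatic carbon, para to a large group.

Among the compounds with values here, no measured pair shows a change of this kind, so the expected size of the step rests on the structural change alone. The expectation is a small step, with a slight drift toward a weaker inhibitor, that may not exceed the scatter; the step from compound 1 to compound 3 is estimated at a 1.9-fold higher number from compound 1 to compound 3 (0.28 log units; within the scatter). For compound 3 in this assay the estimated value is 2500 nM, with a range from 900 nM to 7000 nM.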

Compound 3, half-maximal inhibitory concentration: 4000 nM
Compound 3: middle estimate off by 1.6-fold (0.20 log units), on the low side; measured number inside the range.
By their numbers in this assay, from the lowest: compounds 2 and 1 (each within the scatter of the next); then compound 3.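

Compound 1 and compound 2 differ in more than one place, so they offered no single change to read on its own. In this assay, within the data shown here, the exchange of the 4-bromo-1H-indazol-1-yl group for a bromine-free group with a nitrogen in its six-membered ring gives a 3.1-fold higher number from compound 1 to compound 3 (0.49 log units; beyond the scatter) and so provides the first sign that the group on this aromatic carbon, para to a large group, has a bearing on the read-out, though the step is only modest. Nothing measured here bears on why the number rises.

Two things change together in this step, the bromine goes and a ring carbon becomes a nitrogen, and the compounds shown cannot say how much of the step belongs to each. A close relative that keeps the carbon-only six-membered ring but carries a hydrogen, an amine or a methoxy group where compound 1 has its bromine would begin to separate the two, and would show whether the bromine itself counts for anything.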